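Indole in Place of Hydroxynaphthalene on the Hydrazone Carbon

This account rests on a few compounds, and the source may have more. Where it says the series, first, only, none or still open, it means among the compounds named here.

Within the data shown here, compound 2 `CN(C)CCn1cnnc1-c1cc(Oc2ccc(NC(=O)N/N=C/c3c(O)ccc4ccccc34)cc2F)ccn1` is the only member of this small set with a real number: in a functional assay on A549 cells (Homo sapiens) for cytotoxicity, read by MTT assay, with a stated time of 72 h (on this read-out higher numbers stand for weaker inhibition and lower numbers for stronger inhibition), compound 2 gives 880 nM. Its partner compound 1 `CN(C)CCn1cnnc1-c1cc(Oc2ccc(NC(=O)N/N=C/c3cccc(O)c3)cc2F)ccn1` reaches only a limit of this assay, reported as > 100000 nM, so that value is not a number. The one step that is shown, an at least 110-fold lower number from compound 1 to compound 2 (2.05 log units; beyond the scatter), is therefore known only as a lower bound because the limit of > 100000 nM in this assay, at which 1 of the 2 values shown sits, caps what compound 1 could show.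

Compound 3 `CN(C)CCn1cnnc1-c1cc(Oc2ccc(NC(=O)N/N=C/c3c[nH]c4ccccc34)cc2F)ccn1` carries the change (1H-indol-3-yl in place of 2-hydroxynaphthalen-1-yl on a carbon with a double bond to nitrogen). It bears on the measured step in that the group which arrived there, and produced the large drop in number, is now removed again, while another two-ring group of the same general shape takes its place. Among the measured compounds shown here, the one measured step is large and one-sided, so he expects the number to rise moderately rather than fall, estimating a 3.4-fold higher number from compound 2 to compound 3 (0.53 log units; beyond the scatter). For compound 3 the expected value in this assay is 3000 nM, with a range from 700 nM to 15000 nM.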

Compound 3, half-maximal inhibitory concentration: 820 nM
The estimate for compound 3 lay 3.7-fold (0.56 log units) above the measured number; low and high end bracket the measured number.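

On the carbon with a double bond to nitrogen, 1H-indol-3-yl and 2-hydroxynaphthalen-1-yl cannot be told apart in this assay: the exchange gives a 1.1-fold lower number from compound 2 to compound 3 (0.03 log units; within the scatter). Among these compounds, the earlier pair showed only one two-ring group at this place, whereas these compounds show a second one, with a five-membered aromatic ring and a ring nitrogen in place of the oxygen of 2-hydroxynaphthalen-1-yl, so a value of this size does not depend on that oxygen or on the naphthalene itself. The comparison with the one-ring 3-hydroxyphenyl group gives an at least 120-fold lower number from compound 1 to compound 3 (2.08 log units; beyond the scatter), which repeats the earlier large step with a different group, and this step too is known only as a lower bound because compound 1 sits at a limit rather than at a number: the limit of > 100000 nM in this assay, at which 1 of the 3 values shown sits.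

The compounds shown leave open whether the second ring alone accounts for the step, as a plain naphthalen-1-yl or an unsubstituted phenyl would test. On these data alone, it also remains open how far this place tolerates further change, for example a methoxy group or a chlorine on the indole, or a quinoline in its place.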